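A few compounds are considered here, and "the series" means these few. Any claim that something is new, unique, unknown or untested is made for them only; others in the source may bear on it.

Measured so far:
Compound 1 `CC(=O)Nc1ncnc2c1ccn2-c1ccc(NC(=O)Nc2ccc(Cl)c(C(F)(F)F)c2)cc1`; in a functional assay on A375P cells (Homo sapiens) for antiproliferative activity, read by MTT assay, with a stated time of 24 h (a higher number here means a weaker inhibitor, a lower number a stronger inhibitor), compound 1 gives > 10000 nM, which is a limit of the assay and not a number.
Compound 2 `O=C(Nc1ccc(-n2ccc3c(NC(=O)c4ccccc4)ncnc32)cc1)Nc1ccc(Cl)c(C(F)(F)F)c1`; in this assay compound 2 gives 4600 nM.

Compound 2 thus holds the only number shown; the other value is a limit (the limit of > 10000 nM in this assay, at which 1 of the 2 values shown sits). Going by the values given here, the one measured step, an at least 2.1-fold lower number from compound 1 to compound 2 (0.33 log units; beyond the scatter), follows phenyl in place of methyl on a carbonyl carbon. Compound 3 `Nc1ncnc2c1ccn2-c1ccc(NC(=O)Nc2ccc(Cl)c(C(F)(F)F)c2)cc1` moves the other way: hydrogen in place of benzoyl on a nitrogen on an aromatic ring. Because the lower number in an at least 2.1-fold lower number from compound 1 to compound 2 (0.33 log units; beyond the scatter) came with the benzoyl present, its removal is expected to raise the number in this assay by about a 2.0-fold higher number from compound 2 to compound 3 (0.29 log units; within the scatter), with a fair chance that only a limit is reported. Compound 3 is therefore estimated at 9000 nM, between 3000 nM and 30000 nM.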

Compound 3, half-maximal inhibitory concentration: 8100 nM
Beside the measured number, compound 3's estimate is 1.1-fold (0.05 log units) above it; the range from low to high includes it.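

On the nitrogen on an aromatic ring, the change from benzamido to amino gives a 1.8-fold higher number from compound 2 to compound 3 (0.25 log units; within the scatter), so in this assay the benzoyl is not shown to be needed for activity at this level. Replacing acetyl with hydrogen gives an at least 1.2-fold lower number from compound 1 to compound 3 (0.09 log units; that floor lies within the scatter), so this pair has no readable order. Compound 1 stands at a limit, not a number: the limit of > 10000 nM in this assay, at which 1 of the 3 values shown sits.

On these data alone, whether a butanoyl, a methyl or a methanesulfonyl on this nitrogen would separate from the amino remains open. So does whether the acetyl and the benzoyl differ by more than the limit can show.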